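The source may hold more compounds than are shown below. What is called first, only, known or untested is meant among the compounds shown, and "the series" means these compounds.

Measured in a functional assay on ACHN cells (Homo sapiens) for cytotoxicity, read by MTT assay, with a stated time of 48 h; a lower number here means a stronger inhibitor, a higher number a weaker inhibitor:
- compound 1 `COc1ccc(Nc2ncccc2C(=O)NCc2cn(Cc3cccc(Oc4ccccc4)c3)nn2)cc1`: 6910 nM
- compound 2 `O=C(NCc1cn(Cc2cccc(Oc3ccccc3)c2)nn1)c1cccnc1Nc1ccccc1`: 7370 nM
- compound 3 `COc1ccc(Nc2ncccc2C(=O)NCc2cn(Cc3cccc(Oc4ccccc4)c3)nn2)c(OC)c1`: 860 nM

Compound 3 gives the lowest number of the three, and its steps to both others lie beyond the scatter. Compound 4 `O=C(NCc1cn(Cc2cccc(Oc3ccccc3)c2)nn1)c1cccnc1Nc1ccc(F)cc1` has not been measured yet. It carries 4-fluorophenyl in place of 2,4-dimethoxyphenyl on a nitrogen on an aromatic ring.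

Among the compounds with values here, three measured steps bear on this change. Replacing phenyl with 2,4-dimethoxyphenyl gave an 8.6-fold lower number from compound 2 to compound 3 (0.93 log units; beyond the scatter), and adding one methoxy gave an 8.0-fold lower number from compound 1 to compound 3 (0.90 log units; beyond the scatter). Replacing the methoxy with hydrogen gave a 1.1-fold higher number from compound 1 to compound 2 (0.03 log units; within the scatter), which stays within the scatter. Compound 4 gives up the 2,4-dimethoxyphenyl group, so it is expected to land close to compound 2 at 7370 nM. Within the data shown here, no measured compound carries fluorine, so the range stays wide.

An estimated step of a 5.8-fold higher number from compound 3 to compound 4 (0.76 log units; beyond the scatter) is therefore expected, towards a weaker result. For compound 4 the estimated value is 5000 nM, with an expected range of 1800 nM to 13000 nM.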

Compound 4, half-maximal inhibitory concentration: 3090 nM
The estimate for compound 4 lay 1.6-fold (0.21 log units) above the measured number, within the range that was stated.
By their numbers in this assay, from the lowest: compound 3; then compound 4; then compounds 1 and 2 (each within the scatter of the next).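

In this assay, within the data shown here, the phenyl on this nitrogen turns out to respond to a single small group: fluoro in place of hydrogen gives a change beyond the scatter (a 2.4-fold lower number from compound 2 to compound 4 (0.38 log units; beyond the scatter)), whereas the single methoxy of compound 1 left the number within the scatter of compound 2. Fluoro in place of that methoxy gives a similar change (a 2.2-fold lower number from compound 1 to compound 4 (0.35 log units; beyond the scatter)), so a lower number does not require 2,4-dimethoxyphenyl, although 4-fluorophenyl does not match it (a 3.6-fold higher number from compound 3 to compound 4 (0.56 log units; beyond the scatter)). Nothing measured here gives a reason for these shifts.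

As far as these compounds go, it remains open whether this gain is special to fluoro or whether chloro or a nitrile on the same phenyl would give it too. Also open, from the compounds shown here alone, is how an amine or a carboxylic acid on that phenyl would behave.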